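Swapping the side chain on a pyrazoline-type cytotoxic series

This account rests on a few compounds, and the source may have more. Where it says the series, first, only, none or still open, it means among the compounds named here.

Measured compounds:
- compound 1 `CC1=NN(C(=O)COc2ccc(Cl)cc2)C(c2ccccc2O)C1`: 38800 nM
- compound 2 `CC1=NN(C(=O)CCc2ccccc2)C(c2cc(Br)ccc2O)C1`: 16300 nM

In a functional assay on PC-3 cells (Homo sapiens) for cytotoxicity, read by MTT assay, with a stated time of 48 h (on this read-out higher numbers stand for weaker inhibition and lower numbers for stronger inhibition), compound 2 gives the lower of the two numbers, and compound 1 stands a gap away that is beyond the scatter. Compound 3 `CC1=NN(C(=O)COc2ccc(Cl)cc2)C(c2cc(Br)ccc2O)C1` is not yet measured; it differs from compound 2 by 4-chlorophenoxy in place of benzyl on a saturated chain carbon bound to a carbonyl carbon. The same 4-chlorophenoxy group is present in compound 1, whose value in this assay is the weaker one, so a modest weakening is expected, with the step of a 1.5-fold higher number from compound 2 to compound 3 (0.19 log units; within the scatter) likely close to the scatter. Compound 3 is therefore expected to give about 25000 nM, within a range from 9000 nM to 70000 nM.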

Compound 3, half-maximal inhibitory concentration: 49000 nM
For compound 3 the middle estimate is 2.0-fold (0.29 log units) below the measured one; measured number inside the range.
By their numbers in this assay, from the lowest: compound 2; then compounds 1 and 3 (each within the scatter of the next).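

In this assay the side chain now has a clean comparison of its own: with the bromo kept, 4-chlorophenoxy in place of benzyl gives a 3.0-fold higher number from compound 2 to compound 3 (0.48 log units; beyond the scatter) on this saturated chain carbon. With 4-chlorophenoxy kept, bromo in place of hydrogen on an aromatic carbon gives a 1.3-fold higher number from compound 1 to compound 3 (0.10 log units; within the scatter) and so shows no clear change. No measurement at hand offers a reason for either step. On these data alone, whether bromo matters alongside the benzyl chain stays open, as does how an amine or a longer chain would read at this position.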